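The compounds below may be only part of what the source reports. "The series", "measured", "known", "first", "only" and "open" are said of these compounds alone.

Measured in a functional assay on HCT-116 cells (Homo sapiens) for antiproliferative activity, read by MTT assay, with a stated time of 48 h (a lower number here means a stronger inhibitor, a higher number a weaker inhibitor), where each value is a limit of the measurement and not a number:
compound 1 `Cc1cnc(Nc2ccc(C(C)C)cc2)nc1Nc1nc2ccccc2s1` gives > 50000 nM.
compound 2 `COc1cccc(Nc2ncc(C)c(Nc3nc4ccccc4s3)n2)c1` gives > 50000 nM.
compound 3 `Cc1cnc(Nc2ccc(F)cc2)nc1Nc1nc2ccccc2s1` gives > 50000 nM.

Compound 3 stands at the limit of this assay, and the two other measured compounds stand at the same limit; that is the whole content of the limit of > 50000 nM in this assay, at which 3 of the 3 values shown sit. The steps among them, a step that the two limits leave unreadable from compound 1 to compound 2, a step that the two limits leave unreadable from compound 1 to compound 3 and a step that the two limits leave unreadable from compound 2 to compound 3, run between two limits and therefore give no size in either direction.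

Compound 4 `Cc1cnc(Nc2cccc(F)c2)nc1Nc1nc2ccccc2s1` differs from compound 3 by 3-fluorophenyl in place of 4-fluorophenyl on a nitrogen on an aromatic ring. Going by the values given here, no measured step bears on this change with a readable size, since every step in the set lies between two limits. The aryl groups tried on that nitrogen, 4-isopropylphenyl, 3-methoxyphenyl and 4-fluorophenyl, all leave the compound at the limit, and compound 4 stays within that same aryl series with the same atoms joined differently. The expectation is therefore that compound 4 also sits at the limit, the step of a number no higher from compound 3 to compound 4 (the limit leaves the size open) being expected to show nothing beyond the scatter. Compound 4 is estimated at 50000 nM, within a range from 15000 nM to 200000 nM.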

Compound 4, half-maximal inhibitory concentration: 27800 nM
Compound 4: the middle estimate sits 1.8-fold (0.25 log units) above what was measured; measured number inside the range.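

In this assay compound 4 gives 27800 nM, which makes 3-fluorophenyl the only aryl group shown on this nitrogen to yield a number and not a limit: the limit of > 50000 nM in this assay, at which 3 of the 4 values shown sit.

The change of 4-fluorophenyl to 3-fluorophenyl, with the same atoms joined differently, gives an at least 1.7-fold lower number from compound 3 to compound 4 (0.25 log units; that floor lies within the scatter), so the series now has its first readable end, though that floor alone does not establish a real difference. The steps to the other two compounds read alike, an at least 1.7-fold lower number from compound 2 to compound 4 (0.25 log units; that floor lies within the scatter) and an at least 1.7-fold lower number from compound 1 to compound 4 (0.25 log units; that floor lies within the scatter), while the steps among compound 1, compound 2 and compound 3 run between two limits and cannot be read.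

On these data alone, the true size of all three new steps stays open, since each rests on a limit at one end and its floor does not clear the scatter. Also open, as far as these compounds go, is whether a chloro group, a nitrile or an amine in place of the fluoro of compound 4 would give a number at all, and whether any such number would differ from that of compound 4 by more than the scatter.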